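The source may hold more compounds than are shown below. What is called first, only, known or untested is meant among the compounds shown, and "the series" means these compounds.

Measured compounds in this series:
Compound 1, `O=C(Nc1cc2cc[nH]c(=O)c2cc1Cl)C1CNCCC1c1ccccc1`, 6 nM
Compound 2, `CC(C)(C)c1cccc(C2CNCC2C(=O)Nc2cc3cc[nH]c(=O)c3cc2Cl)c1`, 11 nM
Compound 3, `O=C(Nc1cc2cc[nH]c(=O)c2cc1Cl)[C@@H]1CCCNC1`, 47 nM

In an assay on isolated protein for inhibition of Rho-associated protein kinase 2 (Homo sapiens), read by a luciferase reporter (a higher number here means a weaker inhibitor, a lower number a stronger inhibitor), compound 2 gives 11 nM, the second highest of the three numbers. Its nearest neighbour is compound 1 at 6 nM, and that gap lies within the scatter, so the two cannot be told apart. Compound 3, at 47 nM, gives a clearly higher number than compound 2, beyond the scatter.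

The unmeasured compound 4, `O=C(Nc1cc2cc[nH]c(=O)c2cc1Cl)C1CNCC1c1cccc(Br)c1`, differs from compound 2 in one place: bromo in place of tert-butyl on an aromatic carbon, meta to a large group, or 3-(tert-butyl)phenyl to 3-bromophenyl. Going by the values given here, no pair of measured compounds shows this change. Since compound 1 with an unsubstituted ring of carbon only already gives 6 nM, and compound 2 with the tert-butyl group sits within the scatter of it, the group at this position seems to matter little, so no step beyond the scatter is expected: a 1.4-fold lower number from compound 2 to compound 4 (0.14 log units; within the scatter). Compound 4 is therefore estimated at 8 nM, within 3 nM to 25 nM.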

Compound 4, half-maximal inhibitory concentration: 2 nM
Estimate against measurement, compound 4: 4.0-fold (0.60 log units) above; measured number outside the range, below it.
By their numbers in this assay, from the lowest: compound 4; then compounds 1 and 2 (each within the scatter of the next); then compound 3.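

In this assay the exchange of tert-butyl for bromo reads as a 5.5-fold lower number from compound 2 to compound 4 (0.74 log units; beyond the scatter) and lies beyond the scatter. Going by these compounds alone, this shows that the group on this aromatic carbon, meta to a large group, does affect the number, something no earlier pair could show, and that here bromo, with one heavy atom, gives a lower number than tert-butyl, with four. No measurement shown accounts for this step.

Within the data shown here, with only this one pair, it remains open whether the lower number follows the smaller count of heavy atoms or belongs to bromo itself. Chloro, methoxy, an amine or a carboxylic acid on the same carbon would help to separate these readings, and the compounds shown do not say how any of them would behave.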